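Changing the Amide Substituent: An Expectation for Compound 4

The compounds below may be only part of what the source reports. "The series", "measured", "known", "first", "only" and "open" are said of these compounds alone.

Three compounds have been measured in a functional assay on HCT-116 cells (Homo sapiens) for antiproliferative activity, read by MTT assay, with a stated time of 48 h; on this read-out higher numbers stand for weaker inhibition and lower numbers for stronger inhibition:

Compound 1, `COc1cc(-c2nnc(SCC(=O)c3ccccc3)n2N)cc(OC)c1OC`: compound 1 gives 53000 nM
Compound 2, `COc1ccc(C(=O)CSc2nnc(-c3cc(OC)c(OC)c(OC)c3)n2N)cc1`: compound 2 gives 1240 nM
Compound 3, `COc1cccc(NC(=O)CSc2nnc(-c3cc(OC)c(OC)c(OC)c3)n2N)c1`: compound 3 gives 680 nM

Compound 3 has the lowest number of the three. Its distance from compound 1 is large, a 78-fold lower number from compound 1 to compound 3 (1.89 log units; beyond the scatter), while its distance from compound 2 is small, a 1.8-fold lower number from compound 2 to compound 3 (0.26 log units; within the scatter), so compound 2 and compound 3 cannot be told apart on this read-out. The shared core carries a thioether linked to a carbonyl; compound 1 and compound 2 have an aryl ketone there, compound 3 an amide.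

Compound 4, `COc1ccc(CNC(=O)CSc2nnc(-c3cc(OC)c(OC)c(OC)c3)n2N)cc1OC`, keeps the amide but changes the group on its nitrogen: 3,4-dimethoxybenzyl in place of 3-methoxyphenyl on an amide-type nitrogen. Going by the values given here, no measured step swaps an aryl for a benzyl group on this nitrogen. Among the compounds with values here, the one step touching the amide, from a ketone to an anilide, was within the scatter, and the only step that added a methoxy group, a 43-fold lower number from compound 1 to compound 2 (1.63 log units; beyond the scatter), was large but on a ketone aryl. With so little to go on, compound 4 is expected to stay close to compound 3, with a step of a 1.2-fold higher number from compound 3 to compound 4 (0.07 log units; within the scatter) in this assay. The estimate for compound 4 is 800 nM, within a range from 200 nM to 3500 nM.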

Compound 4, half-maximal inhibitory concentration: > 100000 nM
Compound 4: a limit, no number; the forecaster's own chance of this, stated with the estimate: 5%; middle value at least 120-fold (2.09 log units) away from the limit.
By their numbers in this assay, from the lowest: compounds 3 and 2 (each within the scatter of the next); then compound 1. At a limit, above all of these: compound 4.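

On the amide-type nitrogen of the shared core, the choice of group decides a great deal in this assay, as swapping 3-methoxyphenyl for 3,4-dimethoxybenzyl gives an at least 140-fold higher number from compound 3 to compound 4 (2.16 log units; beyond the scatter). As far as these compounds go, compound 4 gives > 100000 nM, which is a limit of the assay and not a number, so the true size of this step stays unknown. The earlier change at the carbonyl, a 1.8-fold lower number from compound 2 to compound 3 (0.26 log units; within the scatter), lay within the scatter and gave no sign of this, whereas the new result shows that a change on this nitrogen alone, with the rest of the molecule untouched, can carry the reading from the lowest of the series to the assay's limit.

This single swap alters two things at once, the carbon link to the ring and the number of methoxy groups on it, so a plain benzyl or a 3-methoxybenzyl group on the same nitrogen would be needed to tell which of the two accounts for the step. The compounds shown also leave open whether this nitrogen needs an aromatic ring at all, a question that a cyclohexyl group or a short alkyl chain in that place could address.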